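This account rests on a few compounds, and the source may have more. Where it says the series, first, only, none or still open, it means among the compounds named here.

Measured compounds:
compound 1 `COC(=O)c1cc(-c2csc(N/N=C/c3cccs3)n2)ccc1OCc1ccccc1` — 84.4%
compound 2 `Fc1ccc(-c2csc(N/N=C/c3ccc(Cl)cc3Cl)n2)cc1` — 92.4%
compound 3 `Fc1ccc(-c2csc(N/N=C/c3cccs3)n2)cc1` — 90.3%

In a functional assay, read by spectrophotometry, with a stated time of 15 min, tested at 60 ug/mL (on this read-out higher numbers stand for a stronger effect at the one concentration tested and lower numbers for a weaker effect), compound 1 gives 84.4%, the lowest of the three numbers shown. The nearest is compound 3 at 90.3% and the furthest compound 2 at 92.4%; both gaps lie within the scatter, so no order among the three can be read from them. Compounds 2 and 3 differ from each other in the same part of the molecule as compounds 1 and 4 do, and their two values show no difference beyond the scatter. For the measured compounds named here, no step between measured compounds is known here, so nothing directly tells how large a step in this assay the change should bring. Compound 4 `COC(=O)c1cc(-c2csc(N/N=C/c3ccc(Cl)cc3Cl)n2)ccc1OCc1ccccc1` is not yet measured. It differs from compound 1 as follows: 2,4-dichlorophenyl in place of thiophen-2-yl on a carbon with a double bond to nitrogen. Given that compound 2 gives 92.4% and compound 3 gives 90.3%, a step of no more than the scatter is expected, in either direction. Compound 4 is estimated at 87% (range 77% to 95%), meaning an expected step of a number 2.6 percentage points higher from compound 1 to compound 4 (within the scatter).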

Compound 4, a percentage reported as inhibition, at one concentration (the size of the read-out at that concentration, not a potency): 66.3%
For compound 4 the middle estimate is 20.7 percentage points above the measured one; the whole stated range lies above it.
By their numbers in this assay, from the lowest: compound 4; then compounds 1, 3 and 2 (each within the scatter of the next).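

In this assay 2,4-dichlorophenyl in place of thiophen-2-yl on a carbon with a double bond to nitrogen brings a number 18.1 percentage points lower from compound 1 to compound 4 (beyond the scatter) on the core of compound 1, so this place is not indifferent to the change in that setting. On the other core the same change leaves compound 3 at 90.3% and compound 2 at 92.4% within the scatter of each other, so across these two pairs the outcome of the change depends on the rest of the molecule. No measurement at hand explains why the two pairs part.

Still open, going by these compounds, is whether the step follows the chlorine atoms or the six-membered ring; an unsubstituted phenyl at this place would separate the two. Also open, on these data alone, is whether the methyl ester plays a part in the step, which a carboxylic acid in its place could test.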